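The source may hold more compounds than are shown below. What is called first, only, known or untested is meant among the compounds shown, and "the series" means these compounds.

Measured compounds in an assay on isolated protein for inhibition of thyroid hormone receptor beta (Homo sapiens), read by fluorescence polarization; on this read-out lower numbers stand for stronger inhibition and higher numbers for weaker inhibition:
Compound 1 `CS(=O)(=O)c1ccc(C(=O)N2CCC(C(=O)N(Cc3ccccc3)c3ccccc3)CC2)cc1[N+](=O)[O-]` gives > 60000 nM, which is a limit of the assay and not a number.
Compound 2 `CCCN(C(=O)CN(C)C(=O)c1ccc(S(C)(=O)=O)c([N+](=O)[O-])c1)c1ccccc1` gives > 60000 nM, likewise a limit.
Compound 3 `CS(=O)(=O)c1ccc(C(=O)N2CCC(C(=O)N3CCC(c4ccccc4)CC3)CC2)cc1[N+](=O)[O-]` gives > 60000 nM, again a limit.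

Among the measured compounds shown here, compound 1 therefore stands at the same limit as the other two measured compounds; no measured compound has given a number in this assay, and no step between two measured values can be drawn. For the measured compounds named here, the only evidence on the series is the limit of > 60000 nM in this assay, at which 3 of the 3 values shown sit, so nothing shows the shared core of compound 1 to have measurable inhibition here.

Compound 4 `CS(=O)(=O)c1ccc(C(=O)N2CCC(C(=O)N(Cc3ccccc3)Cc3ccccc3)CC2)cc1[N+](=O)[O-]` differs from compound 1 in one place: benzyl in place of phenyl on an amide-type nitrogen. With three measured compounds all sitting at the limit, there is no basis for expecting this change to bring compound 4 into the measurable range. The expected step is a number no higher from compound 1 to compound 4 (the limit leaves the size open), that is, none beyond the scatter. For compound 4 the estimate in this assay is 60000 nM, with a range from 20000 nM to 200000 nM, and most likely the assay again returns only a limit.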

Compound 4, half-maximal inhibitory concentration: > 60000 nM
Compound 4: only a limit was reported; the forecaster's own chance of this, stated with the estimate: 90%; the middle value sits exactly at the limit.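

Among the compounds shown here, compound 1 and compound 4 both stand at a limit of the assay and not at a number, so no step between them can be read. The compounds shown leave open whether the shared core can give measurable inhibition at all: the limit of > 60000 nM in this assay, at which 4 of the 4 values shown sit.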